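Chain extension beyond compound 2 in the hydroxycarbamoyl series

A few compounds are considered here, and "the series" means these few. Any claim that something is new, unique, unknown or untested is made for them only; others in the source may bear on it.

In a functional assay on HCT-116 cells (Homo sapiens) for inhibition, read by MTT assay, with a stated time of 72 h (a lower number here means a stronger inhibitor, a higher number a weaker inhibitor), compound 2 (`Nc1ncnc2c1c(-c1cnc3[nH]ccc3c1)nn2CCCCCCCCC(=O)NO`) gives 5460 nM and shares the low end of the numbers with compound 1 (`CNC(=O)CCCCCCCn1nc(-c2cnc3[nH]ccc3c2)c2c(N)ncnc21`) at 6760 nM. The gap between these two, a 1.2-fold lower number from compound 1 to compound 2 (0.09 log units; within the scatter), lies within the scatter. Compound 3 (`Nc1ncnc2c1c(-c1cnc3[nH]ccc3c1)nn2CCCCCC(=O)NO`) stands apart at 63700 nM, as shown by a 9.4-fold higher number from compound 1 to compound 3 (0.97 log units; beyond the scatter) and by a 12-fold higher number from compound 2 to compound 3 (1.07 log units; beyond the scatter).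

Compound 4 (`Nc1ncnc2c1c(-c1cnc3[nH]ccc3c1)nn2CCCCCCCCCC(=O)NO`) extends the chain of compound 2: (hydroxycarbamoyl)methyl in place of hydroxycarbamoyl on a saturated chain carbon, eight bonds along the chain from an aromatic nitrogen. The most relevant measurement is a 12-fold higher number from compound 2 to compound 3 (1.07 log units; beyond the scatter), a large step in which hydroxycarbamoyl replaces 3-(hydroxycarbamoyl)propyl. That step shortens the chain, so it runs opposite to the present change and shows nothing about extension past compound 2. Among the compounds with values here, no measured step covers this extension, and the change itself is small, so only a slight shift towards a lower number is expected. The expected step is a 1.2-fold lower number from compound 2 to compound 4 (0.08 log units; within the scatter), which stays within the scatter. Compound 4 is estimated at 4500 nM, with an expected range from 1800 nM to 12000 nM in this assay.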

Compound 4, half-maximal inhibitory concentration: 18700 nM
Compound 4: the middle estimate sits 4.2-fold (0.62 log units) below what was measured; measured number above the stated range.
By their numbers in this assay, from the lowest: compounds 2 and 1 (each within the scatter of the next); then compound 4; then compound 3.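

Extension past compound 2 does not leave the number in place: a 3.4-fold higher number from compound 2 to compound 4 (0.53 log units; beyond the scatter), and the shift is towards a weaker inhibitor, yet a 3.4-fold lower number from compound 3 to compound 4 (0.53 log units; beyond the scatter), so among the three hydroxycarbamoyl compounds the lowest number stays with compound 2, and both the shorter and the longer chain give higher numbers. Compound 4 also separates from the methylcarbamoyl compound: a 2.8-fold higher number from compound 1 to compound 4 (0.44 log units; beyond the scatter), whereas compound 2 stays within the scatter of compound 1. Nothing measured here explains the loss on extension.

Still open, going by these compounds, is how the number runs for a chain shorter than that of compound 2 but longer than that of compound 3, and for a longer chain than that of compound 4. Also open, on these data alone, is whether a carboxylic acid in place of the hydroxycarbamoyl end on the chain of compound 2 would stay near the number of compound 2.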